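Varying the aryl on the ring nitrogen: compound 3 to compound 4

This account rests on a few compounds, and the source may have more. Where it says the series, first, only, none or still open, it means among the compounds named here.

Compound 1 `O=C(NCCCCc1ccccc1)c1cccc(C2SCC(=O)N2c2ccccc2)c1` gives 89% in a functional assay on MG-63 cells (Homo sapiens) for inhibition, read by CCK-8 assay, with a stated time of 72 h, tested at 1 uM; a lower number here means less inhibition, a higher number more inhibition at the concentration tested (going by the name of the read-out). Compound 2 `Cc1cccc(N2C(=O)CSC2c2cccc(C(=O)NCCCCc3ccccc3)c2)c1` gives 93% in this assay. Compound 3 `O=C(NCCCCc1ccccc1)c1cccc(C2SCC(=O)N2c2ccccc2F)c1` gives 92% in this assay.

Among these three, compound 3 stands second highest, though its gaps to both neighbours are within the scatter: a number 1 percentage points lower from compound 2 to compound 3 (within the scatter) and a number 3 percentage points higher from compound 1 to compound 3 (within the scatter). Compound 4 `COc1ccc(N2C(=O)CSC2c2cccc(C(=O)NCCCCc3ccccc3)c2)c(OC)c1` has not yet been measured. It differs from compound 3 in one place: 2,4-dimethoxyphenyl in place of 2-fluorophenyl on an amide-type nitrogen in a ring.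

Among the compounds with values here, three measured steps bear on this change, all of them touching the aryl on the same ring nitrogen, and all of them small: a number 4 percentage points higher from compound 1 to compound 2 (within the scatter), a number 3 percentage points higher from compound 1 to compound 3 (within the scatter), and the direct aryl-for-aryl swap a number 1 percentage points lower from compound 2 to compound 3 (within the scatter). Since none of these exceeded the scatter, compound 4 is expected to move little in this assay, with no clear direction, giving an estimated step of a number 2 percentage points lower from compound 3 to compound 4 (within the scatter). Compound 4 is therefore estimated at 90%, with a range from 75% to 98%.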

Compound 4, a percentage reported as inhibition, at one concentration (the size of the read-out at that concentration, not a potency): 56%
Compound 4: middle estimate off by 34 percentage points, on the high side; measured number outside the range, below it.
By their numbers in this assay, from the lowest: compound 4; then compounds 1, 3 and 2 (each within the scatter of the next).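

In this assay the aryl on the ring nitrogen proves sensitive after all, with a number 36 percentage points lower from compound 3 to compound 4 (beyond the scatter) and a number 37 percentage points lower from compound 2 to compound 4 (beyond the scatter) as well as a number 33 percentage points lower from compound 1 to compound 4 (beyond the scatter) when 2,4-dimethoxyphenyl enters. Phenyl, 3-methylphenyl and 2-fluorophenyl had stayed within the scatter of one another, so this position accepts some aryl changes but not every one. The entering group counts 10 heavy atoms and 2 hydrogen-bond acceptors against 7 and 0 for 2-fluorophenyl, but no measurement shown explains the drop.

The compounds shown leave open whether 2-methoxyphenyl or 4-methoxyphenyl alone would bring the same fall, since both methoxy groups enter together here. Also open, from the compounds shown here alone, is how a 4-hydroxyphenyl or 4-aminophenyl group on the same nitrogen would compare.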